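Azetidin-1-yl in place of the 4-bromophenylamino group

The compounds below may be only part of what the source reports. "The series", "measured", "known", "first", "only" and "open" are said of these compounds alone.

Among the compounds with values here, compound 3 `O=C1C=C(Nc2ccc(Br)cc2)C(=O)c2c1nc1n2[C@H]2OC[C@@H](O)[C@H]2OC1` gives 1010 nM in a functional assay on MGC-803 cells (Homo sapiens) for inhibition, read by sulforhodamine B assay (on this read-out lower numbers stand for stronger inhibition and higher numbers for weaker inhibition), the lowest of the two numbers measured so far; compound 2 `COc1ccc(NC2=CC(=O)c3nc4n(c3C2=O)[C@H]2OC[C@@H](O)[C@H]2OC4)cc1` gives 1680 nM, and the step of a 1.7-fold lower number from compound 2 to compound 3 (0.22 log units; within the scatter) stays within the scatter. Compound 1 `O=C1C=C(NC2CCCC2)C(=O)c2c1nc1n2[C@H]2OC[C@@H](O)[C@H]2OC1` reaches only the limit > 8000 nM in this assay. Against compound 1 the two aryl amines stand apart: an at least 4.7-fold lower number from compound 1 to compound 2 (0.67 log units; beyond the scatter) and an at least 7.9-fold lower number from compound 1 to compound 3 (0.89 log units; beyond the scatter).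

Compound 4 `O=C1C=C(N2CCC2)C(=O)c2c1nc1n2[C@H]2OC[C@@H](O)[C@H]2OC1` differs from compound 3 by azetidin-1-yl in place of (4-bromophenyl)amino on a double-bonded ring carbon. Within the data shown here, no measured step covers this exact exchange. The nearest guide is compound 1, whose cyclopentyl on the amine nitrogen sits at the limit of > 8000 nM in this assay, at which 1 of the 3 values shown sits, while both aryl groups on that nitrogen gave lower numbers. Azetidin-1-yl is a four-membered non-aromatic ring, nearer in kind to the cyclopentyl of compound 1 than to the 4-bromophenyl of compound 3, so the expected step is an 8.9-fold higher number from compound 3 to compound 4 (0.95 log units; beyond the scatter) toward weaker inhibition, with a fair chance that only a limit is reported. Compound 4 is therefore expected at 9000 nM, with a range from 2500 nM to 30000 nM.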

Compound 4, half-maximal inhibitory concentration: > 16000 nM
Compound 4: a limit, no number; the forecaster's own chance of this, stated with the estimate: 55%; at least 1.7-fold (0.24 log units) between middle value and limit.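

On the double-bonded ring carbon, the loss of the aryl amine now appears with a second non-aromatic ring, this time one that leaves no hydrogen on the attached nitrogen: in this assay there is an at least 15-fold higher number from compound 3 to compound 4 (1.19 log units; beyond the scatter), and an at least 9.5-fold higher number from compound 2 to compound 4 (0.97 log units; beyond the scatter). Compound 4 is reported only as a limit, not a number: the limit of > 16000 nM in this assay, at which 1 of the 4 values shown sits. Compound 1 is also reported only as a limit, and the step from it to compound 4 cannot be read: the limit of > 8000 nM in this assay, at which 1 of the 4 values shown sits.

As far as these compounds go, it remains open whether the aromatic ring or the amine hydrogen matters more at this position, as the two leave together in this exchange. A methyl(phenyl)amino group, which keeps the aromatic ring without that hydrogen, and a benzylamino group, which sets a methylene between the ring and the amine nitrogen, would help to separate the two.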